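The compounds below may be only part of what the source reports. "The series", "measured", "known", "first", "only" and "open" are said of these compounds alone.

Measured in an ADME assay on HepG2 cells (Homo sapiens) for cytotoxicity, read by luminescence, CellTiter-Glo and ATP content, with a stated time of 72 h; on this read-out higher numbers stand for an effect only at larger amounts of compound and lower numbers for an effect already at smaller amounts:

- Compound 1 `COc1ccc(-c2ccc3c(NCCCNCc4cccc(OC)c4O)ccnc3c2)cc1`: 1600 nM
- Compound 2 `CCC(CC)c1ccc2c(NCCCNCc3ccco3)ccnc2c1`: 6760 nM
- Compound 3 `COc1ccc(Oc2ccc3c(NCCCNCc4cccc(OC)c4O)ccnc3c2)cc1`: 5500 nM

Compound 3 sits at the upper end of these numbers, and the usual scatter does not separate it from compound 2. Compound 4 `CCC(CC)c1ccc2c(NCCCNCc3cccc(OC)c3O)ccnc2c1` has pentan-3-yl in place of 4-methoxyphenoxy on an aromatic carbon; the rest of the structure stays as in compound 3. Within the data shown here, only one measured step changes this same place: a 3.4-fold higher number from compound 1 to compound 3 (0.54 log units; beyond the scatter), where 4-methoxyphenoxy replaces 4-methoxyphenyl. It shows that a swap here can move the number, though only modestly. Compound 2 also carries pentan-3-yl and gives 6760 nM, but it differs from compound 4 elsewhere, so it offers only a rough guide. The group swap itself has not been measured on this structure. A modest change, leaning towards a lower number, is therefore expected in this assay. The expected step is a 1.4-fold lower number from compound 3 to compound 4 (0.16 log units; within the scatter). For compound 4 the estimated value is 3800 nM, with an expected range from 1300 nM to 9500 nM.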

Compound 4, half-maximal effective concentration: 410 nM
Compound 4: the middle estimate sits 9.3-fold (0.97 log units) above what was measured; the measured number lies below the stated range.
By their numbers in this assay, from the lowest: compound 4; then compound 1; then compounds 3 and 2 (each within the scatter of the next).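

In this assay, putting pentan-3-yl, which has no ring, in place of 4-methoxyphenoxy on the aromatic carbon gives a 13-fold lower number from compound 3 to compound 4 (1.13 log units; beyond the scatter) and so shows that this position can move the number much further than the earlier swap between two ring-bearing groups suggested. The same group in place of 4-methoxyphenyl gives a 3.9-fold lower number from compound 1 to compound 4 (0.59 log units; beyond the scatter) and so places compound 4 lower than both ring-bearing compounds here, meaning its effect on the cells already appears at smaller amounts. Pentan-3-yl alone does not set the number, since 2-hydroxy-3-methoxyphenyl in place of furan-2-yl on the chain gives a 16-fold lower number from compound 2 to compound 4 (1.22 log units; beyond the scatter) with that group present in both compounds.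

As far as these compounds go, how a cyclohexyl ring or a shorter chain such as ethyl would behave at the aromatic carbon remains open. Nothing measured here accounts for these drops.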